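This account rests on a few compounds, and the source may have more. Where it says the series, first, only, none or still open, it means among the compounds named here.

In a functional assay on HepG2 cells (Homo sapiens) for antiproliferative activity, read by MTT assay, with a stated time of 48 h (a higher number here means a weaker inhibitor, a lower number a stronger inhibitor), compound 1 (`Cc1ccc(-c2nc(NO)c3cc(Cl)ccc3n2)cc1`) gives 23.1 ug/mL. Compound 3 (`Cc1ccc(-c2nc3ccc(Cl)cc3c(=S)n2N)cc1`) gives 17 ug/mL, which lies within the scatter of compound 1. Compound 2 (`Cc1ccc(-c2nc3ccc(Cl)cc3c(=S)o2)cc1`) gives 11.1 ug/mL, and this lower number lies just beyond the scatter from compound 1. Compound 4 (`Cc1ccc(-c2nc(SCCO)c3cc(Cl)ccc3n2)cc1`) carries (2-hydroxyethyl)sulfanyl in place of hydroxyamino on an aromatic carbon, next to the ring nitrogen: (2-hydroxyethyl)sulfanyl in place of hydroxyamino on an aromatic carbon. Among the measured compounds shown here, no measured pair differs in one place, so the data hold no direct measure of this change. Only a small step is expected in this assay, toward a lower number and probably within the scatter: the estimated move is a 1.4-fold lower number from compound 1 to compound 4 (0.16 log units; within the scatter). For compound 4 the expected value is 16 ug/mL, with an estimated range of 7 ug/mL to 35 ug/mL.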

Compound 4, half-maximal inhibitory concentration: 9.04 ug/mL
Compound 4: the middle estimate sits 1.8-fold (0.25 log units) above what was measured; low and high end bracket the measured number.
By their numbers in this assay, from the lowest: compounds 4, 2, 3 and 1 (each within the scatter of the next, the first and the last beyond it).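

In this assay, among the compounds shown here, the first step at this position is a modest one: (2-hydroxyethyl)sulfanyl in place of hydroxyamino on an aromatic carbon, next to the ring nitrogen, gives a 2.6-fold lower number from compound 1 to compound 4 (0.41 log units; beyond the scatter). The larger group therefore does not cost activity here, and the number moves the favourable way. No measured evidence bears on why. Going by these compounds, whether the sulfur or the terminal hydroxyl goes with the lower number stays open, and so does how a plain amine, a carboxylic acid or a longer chain would read on this carbon.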